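From Dichlorophenyl to Trimethoxyphenyl on the Hydrazone Carbon

A few compounds are considered here, and "the series" means these few. Any claim that something is new, unique, unknown or untested is made for them only; others in the source may bear on it.

Compound 1 `Cc1nc(N(C)C(=O)NC(=O)c2c(F)cccc2F)sc1C(=O)N/N=C/c1ccccc1Cl` gives > 100 ug/mL in a functional assay on HepG2 cells (Homo sapiens) for inhibition, read by MTT assay, with a stated time of 72 h (on this read-out lower numbers stand for stronger inhibition and higher numbers for weaker inhibition), a limit of the assay rather than a number. Compound 2 `Cc1nc(N(C)C(=O)NC(=O)c2c(F)cccc2F)sc1C(=O)N/N=C/c1ccccc1` gives 54.3 ug/mL. Compound 3 `Cc1nc(N(C)C(=O)NC(=O)c2c(F)cccc2F)sc1C(=O)N/N=C/c1ccc(Cl)cc1Cl` gives 70 ug/mL.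

Compound 3 thus carries the highest of the two numbers shown, with compound 2 nearest: a 1.3-fold higher number from compound 2 to compound 3 (0.11 log units; within the scatter). Compound 4 `COc1cc(/C=N/NC(=O)c2sc(N(C)C(=O)NC(=O)c3c(F)cccc3F)nc2C)cc(OC)c1OC` differs from compound 3 by 3,4,5-trimethoxyphenyl in place of 2,4-dichlorophenyl on a carbon with a double bond to nitrogen. The measured steps that touch this same aryl group are an at least 1.8-fold lower number from compound 1 to compound 2 (0.26 log units; that floor lies within the scatter), an at least 1.4-fold lower number from compound 1 to compound 3 (0.15 log units; that floor lies within the scatter) and a 1.3-fold higher number from compound 2 to compound 3 (0.11 log units; within the scatter), none of which exceeds the scatter, so no step beyond the scatter is expected in this assay in either direction. Compound 4 is therefore estimated at 70 ug/mL, within 30 ug/mL to 160 ug/mL, an expected step of no change at the digits printed from compound 3 to compound 4 (within the scatter).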

Compound 4, half-maximal inhibitory concentration: > 100 ug/mL
Compound 4: a limit, no number; the forecaster's own chance of this, stated with the estimate: 35%; middle value at least 1.4-fold (0.15 log units) away from the limit.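

In this assay compound 4, with 3,4,5-trimethoxyphenyl on the carbon with a double bond to nitrogen, gives only a limit of the assay and no number. The steps, an at least 1.4-fold higher number from compound 3 to compound 4 (0.15 log units; that floor lies within the scatter) and an at least 1.8-fold higher number from compound 2 to compound 4 (0.26 log units; that floor lies within the scatter), have floors inside the scatter and so do not separate compound 4 from compound 3 or compound 2, while the step to compound 1 cannot be read. A ring with hydrogen-bond acceptors thus joins the 2-chlorophenyl of compound 1 at this limit: the limit of > 100 ug/mL in this assay, at which 2 of the 4 values shown sit.

As far as these compounds go, how an amine or a carboxylic acid on this ring would read stays open. The shared core does not vary here, so its part in these values cannot be told.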